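Series notes: replacing the aryloxy linker in compound 3

A few compounds are considered here, and "the series" means these few. Any claim that something is new, unique, unknown or untested is made for them only; others in the source may bear on it.

Of the compounds shown here, three have been measured. In a functional assay on CHO cells for agonist activity at Free fatty acid receptor 1 (Homo sapiens), read by FLIPR and calcium flux, tested at 1 uM (a higher number here means that more compound is needed for the effect, a lower number that less compound is needed), compound 1 `Cc1ccc(C)c(OCc2nnc(C(=O)Nc3ccc(CCC(=O)O)cc3)s2)c1` gives 1530 nM, compound 2 `CCc1ccc(OCc2nnc(C(=O)Nc3ccc(CCC(=O)O)cc3)s2)cc1` gives 1170 nM, and compound 3 `Cc1ccccc1OCc1nnc(C(=O)Nc2ccc(CCC(=O)O)cc2)s1` gives 1520 nM. The steps of a 1.3-fold lower number from compound 1 to compound 2 (0.12 log units; within the scatter), a 1.0-fold lower number from compound 1 to compound 3 (0.00 log units; within the scatter) and a 1.3-fold higher number from compound 2 to compound 3 (0.11 log units; within the scatter) are all within the scatter, so compound 3 sits among the other two without a separation that the numbers can support.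

The next compound, compound 4 `O=C(O)CCc1ccc(NC(=O)c2nnc(Cc3cccc(F)c3)s2)cc1`, differs from compound 3 by 3-fluorophenyl in place of 2-methylphenoxy on a saturated chain carbon bound to an aromatic carbon. For the measured compounds named here, none of the measured steps bears on this change directly: the steps from compound 1 to compound 2 and from compound 2 to compound 3 exchange one aryl group for another on the oxygen, whereas here the oxygen itself leaves with the aryl and a 3-fluorophenyl takes its place on the chain carbon. Going by the values given here, the only guidance is that the three aryl variations so far left this assay unchanged within the scatter.

For compound 4 the expectation is therefore a step of a 1.2-fold higher number from compound 3 to compound 4 (0.07 log units; within the scatter), that is, nothing beyond the scatter, but with a wider range given the uncovered change. Compound 4 is estimated at 1800 nM, between 600 nM and 6000 nM.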

Compound 4, half-maximal effective concentration: 5020 nM
Estimate against measurement, compound 4: 2.8-fold (0.45 log units) below, and the stated range covers the measured number.
By their numbers in this assay, from the lowest: compounds 2, 3 and 1 (each within the scatter of the next); then compound 4.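

At this position the oxygen cannot be treated like the aryl groups: exchanges among the aryl groups on the oxygen stayed within the scatter, whereas 3-fluorophenyl in place of the aryloxy group in this assay gives (a 3.3-fold higher number from compound 3 to compound 4 (0.52 log units; beyond the scatter)). The same holds against the other two aryloxy compounds, with (a 3.3-fold higher number from compound 1 to compound 4 (0.52 log units; beyond the scatter)) and (a 4.3-fold higher number from compound 2 to compound 4 (0.63 log units; beyond the scatter)), so the number for compound 4 lies beyond the scatter of all three, whichever aryloxy group leaves. No measurement at hand accounts for this difference.

The change removes the oxygen and alters the aryl substitution in a single step, so the compounds shown do not separate the contribution of the oxygen from that of the 3-fluorophenyl group. A 2-methylbenzyl group would test the loss of the oxygen with the aryl group of compound 3 kept, and an amine nitrogen or a sulfur atom in place of that oxygen would show whether another atom at this place keeps the number of compound 3.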